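Nitro Substitution Tested on a Trifluoromethyl Ketone

The source may hold more compounds than are shown below. What is called first, only, known or untested is meant among the compounds shown, and "the series" means these compounds.

Compound 1 `Nc1ccccc1NC(=O)CCCCCCc1nc(-c2ccccc2)no1` gives 23900 nM in a functional assay on A549 cells (Homo sapiens) for antiproliferative activity, read by MTT assay, with a stated time of 72 h; a lower number here means a stronger inhibitor, a higher number a weaker inhibitor.
Compound 2 `Nc1ccccc1NC(=O)CCCCCCc1nc(-c2ccc([N+](=O)[O-])cc2)no1` reaches only the assay limit, > 100000 nM, in this assay.
Compound 3 `O=C(CCCCCCc1nc(-c2ccccc2)no1)C(F)(F)F` gives 7680 nM in this assay.

Compound 4 `O=C(CCCCCCc1nc(-c2cccc([N+](=O)[O-])c2)no1)C(F)(F)F` has not yet been measured. Its core and that of compound 1 differ by trifluoromethyl in place of (2-aminophenyl)amino on a carbonyl carbon, a change that gave a 3.1-fold lower number from compound 1 to compound 3 (0.49 log units; beyond the scatter). Compound 4 then carries the same kind of change that turned compound 1 into compound 2. In compound 2 the change is nitro in place of hydrogen on an aromatic carbon, while in compound 4 it is nitro in place of hydrogen on an aromatic carbon: in compound 2 the nitro group sits para to a large group, in compound 4 meta to a large group. In the measured pair the change gave an at least 4.1-fold higher number from compound 1 to compound 2 (0.62 log units; beyond the scatter), with compound 2 sitting at the limit of > 100000 nM in this assay, at which 1 of the 3 values shown sits. Because the same kind of change gave an at least 4.1-fold higher number from compound 1 to compound 2 (0.62 log units; beyond the scatter) for compound 2, a weakening step is expected for compound 4 as well, a 3.3-fold higher number from compound 3 to compound 4 (0.51 log units; beyond the scatter), though this rests on one pair and on a different place for the group. Compound 4 is therefore estimated at 25000 nM, expected to fall between 8000 nM and 100000 nM.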

Compound 4, half-maximal inhibitory concentration: 9580 nM
Beside the measured number, compound 4's estimate is 2.6-fold (0.42 log units) above it; measured number inside the range.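

The nitro group makes no measurable difference on the trifluoromethyl ketone in this assay, where the result is a 1.2-fold higher number from compound 3 to compound 4 (0.10 log units; within the scatter). The weakening seen on the core of compound 1 therefore did not carry over to this core, and the two steps differ: the same change on two cores in this assay, an at least 4.1-fold higher number (0.62 log units; beyond the scatter) from compound 1 to compound 2 and a 1.2-fold higher number (0.10 log units; within the scatter) from compound 3 to compound 4, at least 3.3-fold (0.52 log units) apart, beyond the scatter of two such steps. As far as these compounds go, this does not separate the effect of the core from the effect of the nitro group's place, since that group sits meta to a large group in compound 4 but elsewhere on the ring in compound 2; compound 2 also gives only a limit of the assay, so the true size of its step stays unknown.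

The compounds shown leave open whether a nitro group in the place it holds in compound 4 would weaken the core of compound 1, and whether one in the place it holds in compound 2 would change the trifluoromethyl ketone. Also open, from the compounds shown here alone, is how an amine or a carboxylic acid in place of the nitro group, or a longer chain, would behave on either core.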